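Pyridazinone ethers: benzyl versus methyl on the ring nitrogen

The compounds below may be only part of what the source reports. "The series", "measured", "known", "first", "only" and "open" are said of these compounds alone.

Measured compounds:
- compound 1, `O=c1ccc(COCc2ccccc2)nn1Cc1ccccc1`: in a functional assay on aorta (Rattus norvegicus) (on this read-out higher numbers stand for weaker inhibition and lower numbers for stronger inhibition), compound 1 gives 35300 nM
- compound 2, `Cn1nc(COCc2ccccc2)ccc1=O`: in this assay compound 2 reaches only the limit > 100000 nM
- compound 3, `Cn1nc(CCO[Si](c2ccccc2)(c2ccccc2)C(C)(C)C)ccc1=O`: in this assay compound 3 gives 47000 nM

Among the compounds with values here, the one counted change within the measured set is phenyl in place of hydrogen on a saturated chain carbon bound to an aromatic nitrogen; it gives an at least 2.8-fold lower number from compound 2 to compound 1 (0.45 log units; beyond the scatter), and the size of that step is known only as a lower bound because of the limit of > 100000 nM in this assay, at which 1 of the 3 values shown sits. Compound 3 and compound 1 sit within the scatter of each other; the difference between the cores of compound 3 and compound 2 is not broken down here.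

Compound 4, `CC(C)(C)[Si](OCCc1ccc(=O)n(Cc2ccccc2)n1)(c1ccccc1)c1ccccc1`, has not yet been measured. It differs from compound 3 by phenyl in place of hydrogen on a saturated chain carbon bound to an aromatic nitrogen, the same change that separates compound 2 from compound 1. The step is expected to read a 3.4-fold lower number from compound 3 to compound 4 (0.53 log units; beyond the scatter), because an at least 2.8-fold lower number from compound 2 to compound 1 (0.45 log units; beyond the scatter) points that way. Compound 4 is therefore estimated at 14000 nM in this assay, with a range from 5000 nM to 40000 nM.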

Compound 4, half-maximal inhibitory concentration: > 100000 nM
Compound 4 ended at the assay's limit; the forecaster's own chance of this, stated with the estimate: 5%; middle value at least 7.1-fold (0.85 log units) from the limit.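

Phenyl in place of hydrogen on a saturated chain carbon bound to an aromatic nitrogen gives, on the core of compound 3 in this assay, an at least 2.1-fold higher number from compound 3 to compound 4 (0.32 log units; beyond the scatter). Set beside the earlier step, the same change runs the opposite way, so its direction does not carry from one of these cores to the other: the same change on two cores in this assay, an at least 2.8-fold lower number (0.45 log units; beyond the scatter) from compound 2 to compound 1 and an at least 2.1-fold higher number (0.32 log units; beyond the scatter) from compound 3 to compound 4, at least 6.0-fold (0.78 log units) apart, beyond the scatter of two such steps

Compound 4 reads > 100000 nM, a limit and not a number, so the true size of the step stays unknown, and two pairs give no rule for any further core: the limit of > 100000 nM in this assay, at which 2 of the 4 values shown sit.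

Which part of the cores decides the direction of the step remains open, as the difference between the cores of compound 3 and compound 2 is not broken down. Also open, as far as these compounds go, is how methyl to benzyl reads on a core carrying an amine or a carboxylic acid instead of the silyl ether group.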